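Dropping the Hydroxy from an Azetidine Ring

The source may hold more compounds than are shown below. What is called first, only, known or untested is meant among the compounds shown, and "the series" means these compounds.

Three compounds share one core. Compound 1 `Cc1c(C(=O)O)c(-c2cccc(N3CCN(c4ccc(NS(=O)(=O)c5ccc(N[C@H](CCN6CCC(O)CC6)CSc6ccccc6)c(S(=O)(=O)C(F)(F)F)c5)cc4)CC3)c2)c(-c2ccc(Cl)cc2)n1C(C)C` gives 9 nM in a functional assay on NCI-H1417 cells (Homo sapiens) for inhibition, read by WST assay, with a stated time of 4 days; on this read-out lower numbers stand for stronger inhibition and higher numbers for weaker inhibition. Compound 3 `CCCn1c(C)c(C(=O)O)c(-c2cccc(N3CCN(c4ccc(NS(=O)(=O)c5ccc(N[C@H](CCN6CCC(O)CC6)CSc6ccccc6)c(S(=O)(=O)C(F)(F)F)c5)cc4)CC3)c2)c1-c1ccc(Cl)cc1` gives 105 nM in this assay. Compound 2 `Cc1c(C(=O)O)c(-c2cccc(N3CCN(c4ccc(NS(=O)(=O)c5ccc(N[C@H](CCN6CC(O)C6)CSc6ccccc6)c(S(=O)(=O)C(F)(F)F)c5)cc4)CC3)c2)c(-c2ccc(Cl)cc2)n1C` gives 299 nM in this assay, the highest of the three numbers and beyond the scatter from both others, so it is the weakest inhibitor among them. Compound 4 `Cc1c(C(=O)O)c(-c2cccc(N3CCN(c4ccc(NS(=O)(=O)c5ccc(N[C@H](CCN6CCC6)CSc6ccccc6)c(S(=O)(=O)C(F)(F)F)c5)cc4)CC3)c2)c(-c2ccc(Cl)cc2)n1C` differs from compound 2 in one place: hydrogen in place of hydroxy on a saturated ring carbon. Within the data shown here, no measured pair shows this change, so its size is unknown from these data. The expectation is a small step, with the number rising slightly or not at all beyond the scatter, as a 1.3-fold higher number from compound 2 to compound 4 (0.13 log units; within the scatter). Compound 4 is therefore estimated at 400 nM, within a range from 150 nM to 1100 nM.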

Compound 4, half-maximal inhibitory concentration: 126 nM
Beside the measured number, compound 4's estimate is 3.2-fold (0.50 log units) above it, and the stated range ends above it.
By their numbers in this assay, from the lowest: compound 1; then compounds 3 and 4 (each within the scatter of the next); then compound 2.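

Taking the hydroxy off the 3-hydroxyazetidin-1-yl group does not weaken inhibition in this assay: the change gives a 2.4-fold lower number from compound 2 to compound 4 (0.38 log units; beyond the scatter). This hydroxy is therefore not needed for activity in this series, and the plain azetidin-1-yl group serves at least as well at this position. The data on hand give no reason for the gain. Still open, going by these compounds, is whether a fluorine, a methoxy or an amine on that same ring carbon would lower the number further or raise it again.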